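The compounds below may be only part of what the source reports. "The series", "measured", "known", "first", "only" and "open" are said of these compounds alone.

In a functional assay on THP-1 cells (Homo sapiens) for cytotoxicity, read by MTT assay, with a stated time of 24 h (a higher number here means a weaker inhibitor, a lower number a stronger inhibitor), compound 1 `COc1cc(/C=C2\CN(C)C/C(=C\c3ccc(F)cc3)C2=O)cc(OC)c1` gives 5040 nM and compound 2 `COc1cc(/C=C2\CN(C)C/C(=C\c3ccc(Br)cc3)C2=O)cc(OC)c1` gives 4270 nM while compound 3 `COc1cc(/C=C2\CN(C)C/C(=C\c3ccc(Cl)c(Cl)c3)C2=O)cc(OC)c1` gives 3260 nM on the same core. Compound 3 therefore stands level with the other two, as the steps show: a 1.3-fold lower number from compound 2 to compound 3 (0.12 log units; within the scatter) and a 1.5-fold lower number from compound 1 to compound 3 (0.19 log units; within the scatter) are both small, and the same holds for a 1.2-fold lower number from compound 1 to compound 2 (0.07 log units; within the scatter) between the remaining pair.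

Compound 4 `COc1cc(/C=C2\CN(C)C/C(=C\c3ccc(Cl)c(Cl)c3)C2=O)cc(OC)c1OC` differs from compound 3 by a single change methoxy in place of hydrogen on an aromatic carbon in which methoxy stands in place of hydrogen on an aromatic carbon, ortho to two methoxy groups. Within the data shown here, none of the measured steps makes this change, since they only swap halogen-bearing groups elsewhere in the molecule. They are indirect evidence, but with a 1.5-fold lower number from compound 1 to compound 3 (0.19 log units; within the scatter) as the guide, no step beyond the scatter is expected in this assay for this methoxy, and no direction can be favoured. The estimated step is a 1.1-fold lower number from compound 3 to compound 4 (0.04 log units; within the scatter) and it carries real uncertainty. The estimate for compound 4 is 3000 nM (expected range 1200 nM to 7000 nM).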

Compound 4, half-maximal inhibitory concentration: 5330 nM
The estimate for compound 4 lay 1.8-fold (0.25 log units) below the measured number; the measured number falls inside the stated range.
By their numbers in this assay, from the lowest: compounds 3, 2, 1 and 4 (each within the scatter of the next).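

In this assay, among these compounds, the first direct look at this position, methoxy in place of hydrogen on an aromatic carbon, ortho to two methoxy groups, is a 1.6-fold higher number from compound 3 to compound 4 (0.21 log units; within the scatter) and stays within the scatter. A third methoxy on this ring therefore leaves compound 4 level with compound 3, so this one pair shows no sign that the position gains or loses anything with this group. No evidence is at hand that would explain this result.

One small group at one position is all this pair covers. Going by these compounds, whether an amine, a hydroxyl or a carboxylic acid at the same carbon would also stay level with compound 3 remains open, as does whether the added methoxy would behave the same alongside the 4-fluorophenyl of compound 1 or the 4-bromophenyl of compound 2.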